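Furan-2-yl replacing iodo on the shared core

The source may report more compounds than this note shows. Statements on the series, on what has been measured and on what is new or still open speak of the compounds shown alone.

In a functional assay on HL-60 cells (Homo sapiens) for antiproliferative activity, read by XTT assay, with a stated time of 72 h (on this read-out higher numbers stand for weaker inhibition and lower numbers for stronger inhibition), compound 2 `C#Cc1cn([C@@H]2O[C@H](CO)[C@@H](O)[C@H]2O)c2ncnc(OC)c12` gives 190 nM. Compound 3 `COc1ncnc2c1c(I)cn2[C@@H]1O[C@H](CO)[C@@H](O)[C@H]1O` gives 2300 nM, the highest of the two numbers seen so far, and the step of a 12-fold higher number from compound 2 to compound 3 (1.08 log units; beyond the scatter) lies beyond the scatter. Compound 1 `COc1ncnc2c1c(-c1ccccc1)cn2[C@@H]1O[C@H](CO)[C@@H](O)[C@H]1O` gives only a limit of the assay, > 20000 nM (the limit of > 20000 nM in this assay, at which 1 of the 3 values shown sits).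

Compound 4 `COc1ncnc2c1c(-c1ccco1)cn2[C@@H]1O[C@H](CO)[C@@H](O)[C@H]1O` differs from compound 3 in one place: furan-2-yl in place of iodo on an aromatic carbon. The measured step that bears on this is an at least 8.6-fold lower number from compound 1 to compound 3 (0.93 log units; beyond the scatter), where iodo in place of phenyl lowered the number by a modest to large margin. Furan-2-yl reintroduces an aromatic ring at the same position, and the reverse direction, a higher number, is expected, modest to large, possibly reaching the limit. The step expected for compound 4 is a 3.5-fold higher number from compound 3 to compound 4 (0.54 log units; beyond the scatter). Compound 4 is estimated at 8000 nM, within 1500 nM to 40000 nM.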

Compound 4, half-maximal inhibitory concentration: 100 nM
For compound 4 the middle estimate is 80-fold (1.90 log units) above the measured one, and the stated range ends above it.
By their numbers in this assay, from the lowest: compounds 4 and 2 (each within the scatter of the next); then compound 3. At a limit, above all of these: compound 1.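

In this assay, an aromatic ring at this position does not by itself push the number up: furan-2-yl in place of iodo gives a 23-fold lower number from compound 3 to compound 4 (1.36 log units; beyond the scatter), and furan-2-yl in place of phenyl gives an at least 200-fold lower number from compound 1 to compound 4 (2.30 log units; beyond the scatter). Compound 1 stands at a limit of the assay: the limit of > 20000 nM in this assay, at which 1 of the 4 values shown sits. Furan-2-yl and ethynyl are not separated here, with a 1.9-fold lower number from compound 2 to compound 4 (0.28 log units; within the scatter).

On these data alone, whether the ring oxygen of furan-2-yl is needed remains open. Thiophen-2-yl, with sulfur in that ring, or furan-3-yl at the same position would bear on this.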